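A few compounds are considered here, and "the series" means these few. Any claim that something is new, unique, unknown or untested is made for them only; others in the source may bear on it.

Compound 1, `CCCCCc1cccc(NC(=O)NCCCCl)c1`, is the starting point. In a functional assay on M21 cells (Homo sapiens) for antiproliferative activity, with a stated time of 48 h (a higher number here means a weaker inhibitor, a lower number a stronger inhibitor), compound 1 gives 24000 nM. Compound 2, `CCCCC(O)c1cccc(NC(=O)NCCCCl)c1`, carries one change relative to compound 1, (hydroxy in place of hydrogen on a saturated chain carbon bound to an aromatic carbon and a saturated chain carbon). In this assay compound 2 gives 35000 nM, which makes a 1.5-fold higher number from compound 1 to compound 2 (0.16 log units; within the scatter).

Compound 3, `CCCCCc1cccc(NC(=O)CCCCl)c1`, differs from compound 1 in its core, (3-chloropropyl in place of (3-chloropropyl)amino on a carbonyl carbon). For compound 3 this assay reports only a limit, > 100000 nM. That limit is the limit of > 100000 nM in this assay, at which 1 of the 3 values shown sits, and it yields an at least 4.1-fold higher number from compound 1 to compound 3 (0.61 log units; beyond the scatter).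

Compound 4, `CCCCC(O)c1cccc(NC(=O)CCCCl)c1`, is not yet measured. It stands to compound 3 as compound 2 stands to compound 1: the change is hydroxy in place of hydrogen on a saturated chain carbon bound to an aromatic carbon and a saturated chain carbon, the same change at the same place, now on the core of compound 3. The first time this change was made, from compound 1 to compound 2, its step was a 1.5-fold higher number from compound 1 to compound 2 (0.16 log units; within the scatter). Carrying that size over to compound 3, whose value is only a limit, the expected step from compound 3 to compound 4 is a step that the limit leaves unreadable from compound 3 to compound 4. On this basis compound 4 is estimated to give 150000 nM in this assay, most likely again reported only as a limit.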

Compound 4, half-maximal inhibitory concentration: > 100000 nM
Compound 4 ended at the assay's limit (the forecaster's own chance of this, stated with the estimate: 80%); the middle value does not contradict the limit.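

In this assay compound 4 gives only a limit, > 100000 nM, and with compound 3 also reported as a limit, the step from pentyl to 1-hydroxypentyl on this core cannot be read. As far as these compounds go, the swap of (3-chloropropyl)amino for 3-chloropropyl on the carbonyl carbon can still be followed on the hydroxy-bearing pair, where it gives an at least 2.8-fold higher number from compound 2 to compound 4 (0.45 log units; beyond the scatter), and it can be set beside the same swap on the pair without hydroxy: the same change on two cores in this assay, an at least 4.1-fold higher number (0.61 log units; beyond the scatter) from compound 1 to compound 3 and an at least 2.8-fold higher number (0.45 log units; beyond the scatter) from compound 2 to compound 4; the limit leaves it open whether they differ Both steps therefore point towards a weaker inhibitor, but the true size of either step remains unknown, and the data do not show whether the hydroxy group alters the effect of the swap.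

From the compounds shown here alone, it remains open whether an amine or a carboxylic acid on the same saturated chain carbon would behave as hydroxy does. Going by these compounds, it is also open whether a longer chain in place of 3-chloropropyl would bring values back within the range of this assay.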